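The source may hold more compounds than are shown below. What is called first, only, known or untested is meant among the compounds shown, and "the series" means these compounds.

Of the compounds shown here, three sharing one core have been tested in a functional assay on the whole organism (strain Wistar) for inhibition, with Rattus norvegicus as the target, read by paw edema, with stated times of 30 min and 0.5 h, at a dose of 20 mg/kg; on this read-out higher numbers stand for more inhibition at the one dose given (going by the name of the read-out) and lower numbers for less inhibition. Compound 1 `CCOC(=O)C1=C(C)NC(C)=C(C(=O)OCC)C1c1ccc(OCC(=O)NCc2ccccc2)cc1` gives 8.33%. Compound 2 `CCOC(=O)C1=C(C)NC(C)=C(C(=O)OCC)C1c1ccc(OCC(=O)Nc2ccc(C)cc2)cc1` gives 43.9%, and compound 3 `CCOC(=O)C1=C(C)NC(C)=C(C(=O)OCC)C1c1ccc(OCC(=O)NNC(=O)c2cccs2)cc1` gives 44%. Among these three numbers compound 2 stands second highest; its nearest neighbour is compound 3, and the two lie within the scatter of each other, while compound 1 lies well below. The step of a number 35.6 percentage points higher from compound 1 to compound 2 (beyond the scatter) and the step of a number 35.7 percentage points higher from compound 1 to compound 3 (beyond the scatter) are both large, whereas a number 0.1 percentage points higher from compound 2 to compound 3 (within the scatter) is within the scatter.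

Compound 4 `CCOC(=O)C1=C(C)NC(C)=C(C(=O)OCC)C1c1ccc(OCc2nnc(S)o2)cc1` has not yet been measured in this assay. Compared with compound 2 it carries a different group at the chain end: 5-sulfanyl-1,3,4-oxadiazol-2-yl in place of (4-methylphenyl)carbamoyl on a saturated chain carbon bound to an oxygen on an aromatic ring. Among the compounds with values here, none of the measured steps makes this kind of change: they swap one group on the amide-type nitrogen for another, while here the whole (4-methylphenyl)carbamoyl group leaves and a 5-sulfanyl-1,3,4-oxadiazol-2-yl group enters. The measured steps show only that this end of the molecule can move the inhibition a lot, as in a number 35.6 percentage points higher from compound 1 to compound 2 (beyond the scatter), or not at all, as in a number 0.1 percentage points higher from compound 2 to compound 3 (within the scatter). Within the data shown here, with no close precedent, the estimate for compound 4 is 30%, expected to fall between 5% and 55%. For compound 4 this amounts to an expected step of a number 13.9 percentage points lower from compound 2 to compound 4 (beyond the scatter).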

Compound 4, a percentage reported as inhibition, in the whole organism at one dose (the size of the read-out at that dose, not a potency): 42.4%
The estimate for compound 4 lay 12.4 percentage points below the measured number; low and high end bracket the measured number.
By their numbers in this assay, from the lowest: compound 1; then compounds 4, 2 and 3 (each within the scatter of the next).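

In this assay, the amide at the chain end is shown not to be required for this level of inhibition: the whole (4-methylphenyl)carbamoyl group can give way to 5-sulfanyl-1,3,4-oxadiazol-2-yl, which has fewer heavy atoms and a five-membered ring, and the result is a number 1.5 percentage points lower from compound 2 to compound 4 (within the scatter). Against the longer chain end that carries a (thiophen-2-yl)carbonyl group the picture is the same, with a number 1.6 percentage points lower from compound 3 to compound 4 (within the scatter), so three quite different groups now give matching numbers at this position. The benzylcarbamoyl end alone stands apart, with a number 34.1 percentage points higher from compound 1 to compound 4 (beyond the scatter), which makes its low number look like a feature of that one group among the four, not of changes at this position in general. Nothing at hand explains why these different groups match.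

Still open, as far as these compounds go, is whether the sulfanyl group matters, which a methylsulfanyl or amino group on the same ring would test, and whether a plain carboxylic acid on the saturated chain carbon would match these numbers. Because only one dose is shown, these numbers also leave open how the compounds would compare at other doses.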